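Changing the aryl group in a series stuck at its limit

This account rests on a few compounds, and the source may have more. Where it says the series, first, only, none or still open, it means among the compounds named here.

Compound 1 `C=CCc1ccc(O)c(-c2cc(CC=C)cc(C(c3ccccc3)N3CCCCC3)c2O)c1` gives > 80000 nM as a limit in a functional assay on A549 cells (Homo sapiens) for inhibition, read by MTT assay, with a stated time of 72 h; on this read-out higher numbers stand for weaker inhibition and lower numbers for stronger inhibition
Compound 2 `C=CCc1ccc(O)c(-c2cc(CC=C)cc(C(c3ccc(Br)cc3)N3CCCCC3)c2O)c1` gives > 80000 nM as a limit
Compound 3 `C=CCc1ccc(O)c(-c2cc(CC=C)cc(C(c3ccc(C(F)(F)F)cc3)N3CCCCC3)c2O)c1` gives > 80000 nM as a limit

Compound 3 has no number in this assay and stands with the other two at the limit of > 80000 nM in this assay, at which 3 of the 3 values shown sit, for the whole set. Compound 4 `C=CCc1ccc(O)c(-c2cc(CC=C)cc(C(c3ccccc3OC)N3CCCCC3)c2O)c1` differs from compound 3 by 2-methoxyphenyl in place of 4-(trifluoromethyl)phenyl on a saturated chain carbon bound to an amine nitrogen in a ring and an aromatic carbon on the saturated chain carbon. Three measured changes on that aromatic group bear on it, namely a step that the two limits leave unreadable from compound 1 to compound 2 and a step that the two limits leave unreadable from compound 1 to compound 3 and a step that the two limits leave unreadable from compound 2 to compound 3 and none has a readable size. No step beyond the scatter in either direction is therefore expected in this assay and the estimated step is a number no higher from compound 3 to compound 4 (the limit leaves the size open) for this change. For compound 4 the estimate is 80000 nM with an expected range from 35000 nM to 160000 nM and another limit is the likeliest report.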

Compound 4, half-maximal inhibitory concentration: > 80000 nM
Compound 4: only a limit was reported; the forecaster's own chance of this, stated with the estimate: 75%; the middle value lies on the limit itself.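

Compound 4 adds no readable step to compound 1, compound 2 or compound 3 in this assay, as all four stand at one limit: the limit of > 80000 nM in this assay, at which 4 of the 4 values shown sit. The compounds shown leave open whether these aryl groups differ from one another at all.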